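The source may report more compounds than this note shows. Statements on the series, on what has been measured and on what is new or still open speak of the compounds shown alone.

Measured so far:
- compound 1 `CN(C)CCn1c(N)c(-c2nc3ccccc3n2C)c2nc(C#N)c(C#N)nc21`: > 50000 nM
- compound 2 `CCN(CC)CCn1c(N)c(-c2nc3ccccc3n2C)c2nc(C#N)c(C#N)nc21`: > 50000 nM
- compound 3 `CN(C)CCCn1c(N)c(-c2nc3cc(Cl)ccc3[nH]2)c2nc(C#N)c(C#N)nc21`: 10700 nM

In a functional assay on K562 cells (Homo sapiens) for antiproliferative activity, read by MTT assay, with a stated time of 48 h (a higher number here means a weaker inhibitor, a lower number a stronger inhibitor), compound 1 gives > 50000 nM, which is a limit of the assay and not a number. Compound 2 likewise gives > 50000 nM, again a limit. Within the data shown here, compound 3 gives 10700 nM in this assay, the only number in the set. The step that the two limits leave unreadable from compound 1 to compound 2 therefore cannot be sized; it carries the change (diethylamino in place of dimethylamino on a saturated chain carbon, two bonds along the chain from an aromatic nitrogen). How the core of compound 1 and the core of compound 3 differ is not broken down here.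

Compound 4 `CCN(CC)CCCn1c(N)c(-c2nc3cc(Cl)ccc3[nH]2)c2nc(C#N)c(C#N)nc21` has not been measured. It carries diethylamino in place of dimethylamino on a saturated chain carbon, three bonds along the chain from an aromatic nitrogen. The place is not the same as in the change from compound 1 to compound 2: there the group sits two bonds along the chain from an aromatic nitrogen, here three bonds, so this is the same kind of change, not the same change.

The expected step of a 1.1-fold higher number from compound 3 to compound 4 (0.05 log units; within the scatter) is small, resting on compound 1 and compound 2 both sitting at the limit of > 50000 nM in this assay, at which 2 of the 3 values shown sit, which gives no sign that the change moves this assay by much. Compound 4 is estimated at 12000 nM, with a range from 4000 nM to 40000 nM.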

Compound 4, half-maximal inhibitory concentration: 4830 nM
Compound 4: the middle estimate sits 2.5-fold (0.40 log units) above what was measured, and the stated range covers the measured number.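

In this assay, diethylamino in place of dimethylamino on the propyl chain gives a 2.2-fold lower number from compound 3 to compound 4 (0.35 log units; beyond the scatter), so on the core of compound 3 the change has a modest, readable effect. This is a single pair and sets no rule for other cores. On the core of compound 1, with the group two bonds along the chain from an aromatic nitrogen, the step to compound 2 cannot be read, so carry-over between the two cores is neither supported nor contradicted: the limit of > 50000 nM in this assay, at which 2 of the 4 values shown sit.

Still open, going by these compounds, is whether a dipropylamino group or a longer chain on the core of compound 3 would extend the step. Also open, on these data alone, is whether the step appears on any core that gives numbers rather than limits.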